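Triazolo series: methyl on the hydroxyalkyl chain, chloro analog

This account rests on a few compounds, and the source may have more. Where it says the series, first, only, none or still open, it means among the compounds named here.

Measured so far:
compound 1 `CC(O)CNc1nc(-c2ccccc2)nc2c1nnn2Cc1ccccc1F` — 4800000 nM
compound 2 `OCCNc1nc(-c2ccccc2)nc2c1nnn2Cc1ccccc1Cl` — 116000000 nM

In an assay on isolated protein for binding affinity to adenosine receptor A1 (Bos taurus) (a higher number here means a weaker inhibitor, a lower number a stronger inhibitor), compound 2 gives 116000000 nM, the highest of the two numbers measured. Compound 1 gives 4800000 nM in this assay; the two differ in two places, so only the two values themselves are available, and the gap between them lies beyond the scatter.

Compound 3 `CC(O)CNc1nc(-c2ccccc2)nc2c1nnn2Cc1ccccc1Cl` is not yet measured. It differs from compound 2 by methyl in place of hydrogen on a saturated chain carbon bound to an oxygen on a saturated carbon and a saturated chain carbon — methyl in place of hydrogen on a saturated chain carbon bound to an oxygen on a saturated carbon and a saturated chain carbon.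

Among the compounds with values here, no step between measured compounds covers this change. Because compound 1, which carries the same 2-hydroxypropyl chain, gives 4800000 nM, a move toward a lower number is expected, of modest size. For compound 3 the expected step is a 4.6-fold lower number from compound 2 to compound 3 (0.67 log units; beyond the scatter). The estimate for compound 3 in this assay is 25000000 nM, with a range from 4000000 nM to 130000000 nM.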

Compound 3, inhibition constant: 32000000 nM
For compound 3 the middle estimate is 1.3-fold (0.11 log units) below the measured one, and the stated range covers the measured number.
By their numbers in this assay, from the lowest: compound 1; then compound 3; then compound 2.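

In this assay, within the data shown here, the change from 2-hydroxyethyl to 2-hydroxypropyl with the chloro group held fixed gives a 3.6-fold lower number from compound 2 to compound 3 (0.56 log units; beyond the scatter), the first single-place reading at this saturated chain carbon. With the 2-hydroxypropyl chain held fixed, chloro in place of fluoro on an aromatic carbon gives a 6.7-fold higher number from compound 1 to compound 3 (0.82 log units; beyond the scatter), so a change in either place moves the number beyond the scatter. No supporting evidence bears on the reason for either step.

As far as these compounds go, each step rests on a single pair of compounds, so it remains open whether the methyl step would carry over with fluoro in place of chloro. Also open, from the compounds shown here alone, is how a longer chain such as 3-hydroxypropyl, an amine in place of the hydroxyl, or bromo in place of chloro would read in this assay.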